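The source may report more compounds than this note shows. Statements on the series, on what has been measured and on what is new or still open speak of the compounds shown alone.

Measured so far in an ADME assay on HUVEC cells (Homo sapiens) for antiproliferative activity, read by resazurin assay, with a stated time of 72 h; on this read-out higher numbers stand for weaker inhibition of growth and lower numbers for stronger inhibition of growth:
- compound 1 `CCCCCCCCCCCC/C=C\N(NC(=O)COC)C(=O)OC(C)(C)C`: 15800 nM
- compound 2 `CCCCCCCCCCCC/C=C/N(NC(=O)COC)C(=O)OC(C)(C)C`: 36100 nM

Among the measured compounds shown here, compound 2 holds the higher of the two values in this assay; its only neighbour is compound 1, and the step goes a 2.3-fold higher number from compound 1 to compound 2 (0.36 log units; beyond the scatter). That step rests on (the fact that compounds 1 and 2 differ only in the configuration as drawn), the drawn double-bond geometry being the whole of the difference.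

Compound 3 `CCCCCCCC/C=C/N(NC(=O)COC)C(=O)OC(C)(C)C` is the next member. It differs from compound 2 by hydrogen in place of butyl on a saturated chain carbon, eight bonds along the chain from a double-bonded chain carbon. For the measured compounds named here, none of the measured steps touches this part of the molecule: the single step known, from compound 1 to compound 2, concerns configuration only and gives no guide to shortening the saturated chain. With nothing to lean on, the expectation for compound 3 in this assay is a step of about a 1.1-fold higher number from compound 2 to compound 3 (0.04 log units; within the scatter), which is within the scatter, and the direction is left open. The estimate for compound 3 is therefore 40000 nM, with a range from 15000 nM to 110000 nM to cover a shift either way once the chain is cut back.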

Compound 3, concentration for 50% growth inhibition: 49900 nM
Estimate against measurement, compound 3: 1.2-fold (0.10 log units) below; the measured number falls inside the stated range.
By their numbers in this assay, from the lowest: compound 1; then compounds 2 and 3 (each within the scatter of the next).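

In this assay, among the compounds shown here, the first change to the saturated chain, hydrogen in place of butyl on a saturated chain carbon, eight bonds along the chain from a double-bonded chain carbon, gives a 1.4-fold higher number from compound 2 to compound 3 (0.14 log units; within the scatter) and so leaves compound 2 and compound 3 indistinguishable on this read-out. Within these two compounds, the outer part of the chain can therefore go without a change that can be told from repeat scatter, and the chain length tested here matters less than the double-bond geometry, whose step alone lies beyond the scatter: a 2.3-fold higher number from compound 1 to compound 2 (0.36 log units; beyond the scatter) is the only such step in the series so far. For the compounds shown here, the one available piece of information concerns configuration and says nothing about this chain change, so no explanation can be offered for the result.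

Still open, going by these compounds, is whether a chain cut much further back, to propyl or methyl, or a chain ending in an amine or a carboxylic acid, would move the number beyond the scatter. Also open, on these data alone, is whether the shorter chain with the Z double bond would keep the gap seen with the longer chain.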